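The source may hold more compounds than are shown below. What is called first, only, known or untested is meant among the compounds shown, and "the series" means these compounds.

Working notes on the series, read in a functional assay on LNCaP cells (Homo sapiens) for antiproliferative activity, read by propidium iodide staining, with a stated time of 96 h; a higher number here means a weaker inhibitor, a lower number a stronger inhibitor. Compound 1 `CC(O)(CSc1ccc(S(F)(F)(F)(F)F)cc1)C(=O)Nc1ccc(S(F)(F)(F)(F)F)cc1` gives 18300 nM, compound 2 `CC(O)(CSc1cccc(S(F)(F)(F)(F)F)c1)C(=O)Nc1ccc(S(F)(F)(F)(F)F)cc1` gives 25000 nM, and compound 3 `CC(O)(CSc1ccc(F)cc1)C(=O)Nc1ccc(S(F)(F)(F)(F)F)cc1` gives 12500 nM. These three values lie within the scatter of one another, so compound 3 stands level with the other two on these numbers.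

The next change leads to compound 4 `CC(O)(CSc1cccc(C(F)(F)F)c1)C(=O)Nc1ccc(S(F)(F)(F)(F)F)cc1`: 3-(trifluoromethyl)phenyl in place of 4-fluorophenyl on a sulfur, with 3-(trifluoromethyl)phenyl in place of 4-fluorophenyl on a sulfur. Among the measured compounds shown here, the only measured step that bears directly on this place is a 1.5-fold lower number from compound 1 to compound 3 (0.17 log units; within the scatter). No measured change of the group on that sulfur has yet gone beyond the scatter, though the data cover few groups and none of the compounds carries the trifluoromethyl group. No shift beyond the scatter is therefore expected in this assay, and no direction is firmly indicated.

The estimated step is a 1.2-fold higher number from compound 3 to compound 4 (0.08 log units; within the scatter). The expected value for compound 4 is 15000 nM, with an estimated range of 7500 nM to 30000 nM.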

Compound 4, half-maximal inhibitory concentration: 18300 nM
The estimate for compound 4 lay 1.2-fold (0.09 log units) below the measured number; low and high end bracket the measured number.
By their numbers in this assay, from the lowest: compounds 3, 1, 4 and 2 (each within the scatter of the next).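

In this assay the exchange of 4-fluorophenyl for 3-(trifluoromethyl)phenyl on the sulfur gives a 1.5-fold higher number from compound 3 to compound 4 (0.17 log units; within the scatter) and so leaves the number level, even though the entering group is larger by the counts of heavy atoms. The direct exchange of the sulfur-bearing fluorinated group for trifluoromethyl on an aromatic carbon gives a 1.4-fold lower number from compound 2 to compound 4 (0.14 log units; within the scatter) and is likewise level, so the two groups cannot be told apart here. All four compounds thus stand level, and no change on this aryl group has yet gone beyond the scatter, while nothing at hand explains this flat reading.

Every group shown on the sulfur is a fluorinated phenyl, so it remains open whether a carboxylic acid, an amine or a simple unsubstituted phenyl there would move the number beyond the scatter. Going by these compounds, the amide portion also stays open, since all four compounds share the same group on the amide nitrogen.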